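This account rests on a few compounds, and the source may have more. Where it says the series, first, only, none or still open, it means among the compounds named here.

Compound 1 `COC(=O)c1cc(-c2cccc(NC(=O)c3ccc(OCc4ccc(Cl)cc4)cc3)c2)on1`, compound 2 `COC(=O)c1cc(-c2cccc(NC(=O)c3ccc(/C=C/C(=O)c4ccc(OC)cc4)cc3)c2)on1` and compound 3 `CCOC(=O)c1cc(-c2cccc(NC(=O)c3ccc(/C=C/C(=O)c4ccc(Cl)cc4)cc3)c2)on1` share a core and have each been tested in an ADME assay on Vero cells (Chlorocebus sabaeus) for cytotoxicity, read by MTT assay, with a stated time of 72 h; on this read-out lower numbers stand for higher toxicity in this test and higher numbers for lower toxicity in this test. In this assay compound 1 gives > 80 ug/mL, which is a limit of the assay rather than a number. For compound 2 the result in this assay is > 10 ug/mL, again a limit. Compound 3 in this assay gives > 80 ug/mL, also a limit. Compound 2 therefore stands only at a limit, and the two further values shown are limits as well: one sits at the limit of > 10 ug/mL in this assay, at which 1 of the 3 values shown sits, and two sit at the limit of > 80 ug/mL in this assay, at which 2 of the 3 values shown sit. For the measured compounds named here, the only step between compounds that differ in one place, a step that the two limits leave unreadable from compound 1 to compound 2, is left unreadable by the two limits.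

Compound 4 `COC(=O)c1cc(-c2cccc(NC(=O)c3ccc(/C=C/C(=O)c4ccc([N+](=O)[O-])cc4)cc3)c2)on1` has not yet been measured in this assay. It differs from compound 2 by nitro in place of methoxy on an aromatic carbon. Going by the values given here, no measured step bears on this change, and the one step recorded has no readable size, so there is nothing to suggest a shift beyond the scatter. Compound 4 is therefore expected to remain at low toxicity, with a step that the limit leaves unreadable from compound 2 to compound 4 estimated for it. Compound 4 is estimated at 60 ug/mL, within a range of 20 ug/mL to 100 ug/mL, and the result may well be reported only as a limit.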

Compound 4, half-maximal cytotoxic concentration: > 20 ug/mL
Compound 4: no number, only a limit (the forecaster's own chance of this, stated with the estimate: 70%); the middle value is on the limit's open side.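

In this assay compound 4 gives > 20 ug/mL, which is a limit of the assay and not a number. Compound 2 also stands only at a limit, so no step can be read between compound 2 and compound 4. The compounds shown leave open whether nitro in place of methoxy changes the half-maximal cytotoxic concentration at all.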